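From Chloro to Methoxy on an Aromatic Carbon

The compounds below may be only part of what the source reports. "The series", "measured", "known", "first", "only" and "open" are said of these compounds alone.

In a functional assay on SK-OV-3 cells (Homo sapiens) for cytotoxicity (a lower number here means a stronger inhibitor, a higher number a weaker inhibitor), compound 3 `C=C/C=C\[C@H](C)[C@H](OC(N)=O)[C@@H](C)[C@H](O)[C@@H](C)C/C(C)=C\[C@H](C)[C@@H](O)[C@@H](C)/C=C\CCc1cccc(Cl)c1` gives 380 nM. Within the data shown here, compound 2 `C=C/C=C\[C@H](C)[C@H](OC(N)=O)[C@@H](C)[C@H](O)[C@@H](C)C/C(C)=C\[C@H](C)[C@@H](O)[C@@H](C)/C=C\CCc1ccc(C)c(O)c1` gives 410 nM, which lies within the scatter of compound 3, so these two share the low end of the numbers so far. Compound 1 `C=C/C=C\[C@H](C)[C@H](OC(N)=O)[C@@H](C)[C@H](O)[C@@H](C)C/C(C)=C\[C@H](C)[C@@H](O)[C@@H](C)/C=C\CCc1ccc(Oc2ccccc2)cc1` stands far higher, at 10000 nM.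

Compound 4 `C=C/C=C\[C@H](C)[C@H](OC(N)=O)[C@@H](C)[C@H](O)[C@@H](C)C/C(C)=C\[C@H](C)[C@@H](O)[C@@H](C)/C=C\CCc1cccc(OC)c1` keeps everything in compound 3 except one group: methoxy in place of chloro on an aromatic carbon, meta to a large group (methoxy in place of chloro on an aromatic carbon). Among the measured compounds shown here, no measured step makes this exact exchange. The closest evidence is a 1.1-fold lower number from compound 2 to compound 3 (0.03 log units; within the scatter), where 3-chlorophenyl took the place of 3-hydroxy-4-methylphenyl and the number stayed within the scatter. Compound 1 shows that numbers in this series can lie far apart, so one small step is thin support. Even so, no step beyond the scatter is expected in this assay. The expected change is a 1.2-fold higher number from compound 3 to compound 4 (0.07 log units; within the scatter). For compound 4 the estimated value is 450 nM, with an expected range of 150 nM to 1500 nM.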

Compound 4, half-maximal inhibitory concentration: 370 nM
Estimate against measurement, compound 4: 1.2-fold (0.09 log units) above; measured number inside the range.
By their numbers in this assay, from the lowest: compounds 4, 3 and 2 (each within the scatter of the next); then compound 1.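

At this ring carbon, meta to a large group, this assay does not tell chloro and methoxy apart: the exchange gives a 1.0-fold lower number from compound 3 to compound 4 (0.01 log units; within the scatter). Methoxy has one hydrogen-bond acceptor and chloro has none, yet that difference in count leaves no visible mark on the number here. The 3-methoxyphenyl also matches the 3-hydroxy-4-methylphenyl, with a 1.1-fold lower number from compound 2 to compound 4 (0.04 log units; within the scatter), so three different aromatic end groups now sit together within the scatter, and nothing measured here explains why they match.

Going by these compounds, whether the number would stay in this range with an amine, a carboxylic acid or an ethoxy group on the same ring carbon remains open. Also open, on these data alone, is whether methoxy would give a similar number on a different carbon of the ring.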